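Acetyl in Place of Dimethylamino on the Pendant Phenyl

This account rests on a few compounds, and the source may have more. Where it says the series, first, only, none or still open, it means among the compounds named here.

Measured compounds:
compound 1, `COc1cc(C)cc(-c2c(-c3ccnc(-c4ccc(N(C)C)cc4)c3)cnn2CC#N)c1`: > 100000 nM, a limit of the assay, not a number
compound 2, `COc1cc(C)cc(-c2nn(CC#N)cc2-c2ccc(-c3cccc(C(C)=O)c3)nc2)c1`: > 100000 nM, likewise a limit of the assay, not a number

In a functional assay on PC-3 cells (Homo sapiens) for inhibition, read by sulforhodamine B assay, with a stated time of 48 h (a lower number here means that less compound is tolerated, a higher number that more compound is tolerated), compound 1 gives > 100000 nM, which is a limit and not a measured number. Among the compounds with values here, compound 2, with its own arrangement of the same core, also stops at the limit, so the limit of > 100000 nM in this assay, at which 2 of the 2 values shown sit, describes everything measured so far: no compound in the set has yet yielded a number. Compound 1 therefore stands at the top of what the assay can report, with nothing above or below it to compare against.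

Compound 3, `COc1cc(C)cc(-c2c(-c3ccnc(-c4ccc(C(C)=O)cc4)c3)cnn2CC#N)c1`, differs from compound 1 in one place: acetyl in place of dimethylamino on an aromatic carbon. Within the data shown here, with no measured step, the expected step that the limit leaves unreadable from compound 1 to compound 3 is none beyond the scatter, and the estimate for compound 3 is 150000 nM with a range from 60000 nM to 400000 nM, most likely again reported only as a limit.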

Compound 3, concentration lethal to 50% of the cells: > 100000 nM
Compound 3: only a limit was reported (the forecaster's own chance of this, stated with the estimate: 80%); the middle value lies beyond the limit too.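

Compound 3 stops at a limit of the assay, as compound 1 does, so no step can be read between compound 1 and compound 3: the limit of > 100000 nM in this assay, at which 3 of the 3 values shown sit.

The compounds shown leave open how 4-acetylphenyl and 4-(dimethylamino)phenyl compare in this assay, and whether any compound on the shared core gives a number there.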